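Pyridin-4-yl in Place of 2-Hydroxyphenyl

This account rests on a few compounds, and the source may have more. Where it says the series, first, only, none or still open, it means among the compounds named here.

In a functional assay on HepG2 cells (Homo sapiens) for antiproliferative activity, read by MTT assay, with a stated time of 48 h (a higher number here means a weaker inhibitor, a lower number a stronger inhibitor), compound 1 (`CC(=O)N1N=C(c2ccc3ccccc3c2)OC1c1ccccc1Cl`) gives 4.32 ug/mL and compound 2 (`CC(=O)N1N=C(c2ccc3ccccc3c2)OC1c1ccc(F)cc1`) gives 1.82 ug/mL while compound 3 (`CC(=O)N1N=C(c2ccc3ccccc3c2)OC1c1ccccc1O`) gives 1.84 ug/mL and so stands level with compound 2 and apart from compound 1. Compound 4 (`CC(=O)N1N=C(c2ccc3ccccc3c2)OC1c1ccncc1`) carries pyridin-4-yl in place of 2-hydroxyphenyl on a saturated ring carbon. Changing the aromatic group at this carbon gave modest steps in two cases (a 2.4-fold lower number from compound 1 to compound 2 (0.38 log units; beyond the scatter)) and (a 2.3-fold lower number from compound 1 to compound 3 (0.37 log units; beyond the scatter)) and none beyond the scatter in the third (a 1.0-fold higher number from compound 2 to compound 3 (0.00 log units; within the scatter)). Within the data shown here, no tested compound carries pyridin-4-yl, so the data fix no direction. In this assay the expected step (a 1.3-fold higher number from compound 3 to compound 4 (0.12 log units; within the scatter)) stays within the scatter. Compound 4 is estimated at 2.4 ug/mL with 1 ug/mL to 6 ug/mL as its expected range.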

Compound 4, half-maximal inhibitory concentration: 2.17 ug/mL
For compound 4 the middle estimate is 1.1-fold (0.04 log units) above the measured one, and the stated range covers the measured number.
By their numbers in this assay, from the lowest: compounds 2, 3, 4 and 1 (each within the scatter of the next, the first and the last beyond it).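

In this assay, pyridin-4-yl, which has a ring nitrogen and no hydrogen-bond donor, reads level with both 2-hydroxyphenyl (a 1.2-fold higher number from compound 3 to compound 4 (0.07 log units; within the scatter)) and 4-fluorophenyl (a 1.2-fold higher number from compound 2 to compound 4 (0.08 log units; within the scatter)), so the hydroxy group of compound 3 is not required for a number in this range. The gap to the 2-chlorophenyl compound also stays within the scatter (a 2.0-fold lower number from compound 1 to compound 4 (0.30 log units; within the scatter)), leaving compound 4 level with compounds that differ from each other. Nothing available explains why these groups read alike.

Still open is how an aliphatic amine or a short alkyl chain would read at this carbon, since every group shown there is an aromatic ring. As far as these compounds go, replacing the acetyl group, for instance with a propanoyl group, also remains untested in these compounds.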